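Halogen swap on the arylidene group of the acetoxy enones

The source may hold more compounds than are shown below. What is called first, only, known or untested is meant among the compounds shown, and "the series" means these compounds.

Measured compounds:
compound 1 `CC(=O)OC/C(=C\C1CCCCC1)C(=O)c1ccccc1` gives 21000 nM in a functional assay on HBL-100 cells (Homo sapiens) for inhibition, read by sulforhodamine B assay, with a stated time of 48 h; on this read-out higher numbers stand for weaker inhibition of growth and lower numbers for stronger inhibition of growth
compound 2 `CCC(/C=C(\COC(C)=O)C(=O)c1ccccc1)CC` gives > 100000 nM in this assay, which is a limit of the assay and not a number
compound 3 `CC(=O)OC/C(=C\c1ccc(Cl)cc1)C(=O)c1ccccc1` gives 2300 nM in this assay
compound 4 `CC(=O)OC/C(=C\c1ccc(F)cc1)C(=O)c1ccccc1` is not yet measured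

Compound 3 has the lowest of the two numbers given; the nearest measured neighbour stands a 9.1-fold lower number from compound 1 to compound 3 (0.96 log units; beyond the scatter). The reading of compound 2 sits at the limit of > 100000 nM in this assay, at which 1 of the 3 values shown sits.

The step from compound 3 to compound 4 is fluoro in place of chloro on an aromatic carbon. Within the data shown here, none of the measured steps changes a substituent on an intact phenyl: a 9.1-fold lower number from compound 1 to compound 3 (0.96 log units; beyond the scatter), an at least 43-fold lower number from compound 2 to compound 3 (1.63 log units; beyond the scatter) and an at least 4.7-fold higher number from compound 1 to compound 2 (0.67 log units; beyond the scatter) all replace the whole group on the double-bonded chain carbon. These steps show that the group on this carbon matters strongly, but they give no direct reading on a halogen swap within the 4-substituted phenyl. With one halogen exchanged for another, no step beyond the scatter is expected in this assay, and if anything a slightly higher number.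

Compound 4 is therefore estimated at 3500 nM, with a range from 1500 nM to 9000 nM. This estimate means a step of a 1.5-fold higher number from compound 3 to compound 4 (0.18 log units; within the scatter), expected to lie within the scatter.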

Compound 4, concentration for 50% growth inhibition: 17000 nM
Estimate against measurement, compound 4: 4.9-fold (0.69 log units) below; the measured number lies above the stated range.
By their numbers in this assay, from the lowest: compound 3; then compounds 4 and 1 (each within the scatter of the next). At a limit, above all of these: compound 2.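

In this assay the halogen on the aromatic carbon, para to a large group, is not a silent place on the series: a 7.4-fold higher number from compound 3 to compound 4 (0.87 log units; beyond the scatter), so the exchange of a single atom moves the read-out beyond the scatter. With 4-fluorophenyl on the double-bonded chain carbon, the advantage seen for 4-chlorophenyl over cyclohexyl, a 9.1-fold lower number from compound 1 to compound 3 (0.96 log units; beyond the scatter), is no longer seen: a 1.2-fold lower number from compound 1 to compound 4 (0.09 log units; within the scatter), so that earlier step belongs to the chlorinated ring and cannot be read as a general result for a halogen-bearing phenyl. The step from pentan-3-yl remains beyond the scatter, an at least 5.8-fold lower number from compound 2 to compound 4 (0.76 log units; beyond the scatter), but it gives only a bound, as the reading of compound 2 is a limit and not a number: the limit of > 100000 nM in this assay, at which 1 of the 4 values shown sits.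

On these data alone, whether bromo, methyl or methoxy at the same aromatic carbon reads like chloro or like fluoro stays open, as does the reading of an unsubstituted phenyl on the double-bonded chain carbon. The compounds shown also leave open whether the step between chloro and fluoro keeps its size with a hydroxyl or an amine in place of the acetoxy group.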